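Methoxy on the aromatic ring of a pyrrolidine amide

The source may report more compounds than this note shows. Statements on the series, on what has been measured and on what is new or still open speak of the compounds shown alone.

Compound 1, `O=C(CCCCCCc1ccccc1)N1CCCC1`, is a pyrrolidine amide carrying an unsubstituted phenyl ring at the end of its chain. In an assay on HEK293 cells for inhibition of N-acylethanolamine-hydrolyzing acid amidase (Rattus norvegicus), read by LC-MS, with a stated time of 30 min (a lower number here means a stronger inhibitor, a higher number a weaker inhibitor), compound 1 gives 12900 nM, the highest of the two numbers shown, its nearest neighbour being compound 2, `Cc1cccc(CCCCCCC(=O)N2CCCC2)c1`, which in this assay gives 8300 nM; the step of a 1.6-fold lower number from compound 1 to compound 2 (0.19 log units; within the scatter) stays within the scatter. For the measured compounds named here, compound 3, `O=C(CCCCCCc1ccccc1Cl)N1CCCC1`, reaches only the limit of this assay, > 100000 nM, so that the step of an at least 7.7-fold higher number from compound 1 to compound 3 (0.88 log units; beyond the scatter) is the one clear change among the measured compounds, and the evidence for it is the limit of > 100000 nM in this assay, at which 1 of the 3 values shown sits.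

Compound 4, `COc1ccc(CCCCCCC(=O)N2CCCC2)cc1`, has not been measured in this assay. It differs from compound 1 by methoxy in place of hydrogen on an aromatic carbon. Going by the values given here, two measured steps bear on this change: the methyl of compound 2 left the number essentially unchanged, whereas the chloro of compound 3 pushed the number beyond the reach of the assay. Among the compounds with values here, the methoxy of compound 4 sits para to a large group, a placement for which no measured analogue exists, so the expectation must rest on the small ring substituents already seen. Compound 4 is therefore expected to show a step of a 1.8-fold lower number from compound 1 to compound 4 (0.27 log units; within the scatter), within or close to the scatter. Compound 4 is estimated at 7000 nM, with a range from 2500 nM to 25000 nM.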

Compound 4, half-maximal inhibitory concentration: 35400 nM
For compound 4 the middle estimate is 5.1-fold (0.70 log units) below the measured one; the whole stated range lies below it.
By their numbers in this assay, from the lowest: compounds 2 and 1 (each within the scatter of the next); then compound 4. At a limit, above all of these: compound 3.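

The methoxy change gives a 2.7-fold higher number from compound 1 to compound 4 (0.44 log units; beyond the scatter), a modest but real loss in this assay, so a small group para to a large group on the aromatic ring of the core of compound 1 carries a measurable cost. For the compounds shown here, the earlier steps showed a methyl change that stayed within the scatter and a chloro change that ended at a limit; this is the first ring change whose loss has a definite size beyond the scatter. Compound 3 stands at a limit, > 100000 nM, which is not a number, and the methoxy step can therefore show only a smaller loss than a bound allows, not how far apart the two changes lie: the limit of > 100000 nM in this assay, at which 1 of the 4 values shown sits.

From the compounds shown here alone, whether the loss belongs to this position or to methoxy itself stays open, and a hydroxyl or a fluoro at this place, or methoxy on another aromatic carbon, would separate the two. Also open, going by these compounds, is whether an amine on the ring, or a shorter or longer chain, would change how this position responds.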